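The source may hold more compounds than are shown below. What is called first, only, known or untested is meant among the compounds shown, and "the series" means these compounds.

Measured in a functional assay on HL-60 cells (Homo sapiens) for inhibition, read by resazurin assay, with a stated time of 72 h; on this read-out lower numbers stand for stronger inhibition and higher numbers for weaker inhibition:

Compound 1, `CCSc1ccc(C2CC(=O)N2c2cc(OC)c(OC)c(OC)c2)cc1`: 204 nM
Compound 2, `C=CC1C(=O)N(c2cc(OC)c(OC)c(OC)c2)C1c1ccc(SCC)cc1`: 320 nM
Compound 3, `C=CC1C(=O)N(c2cc(OC)c(OC)c(OC)c2)C1c1ccc(OC)cc1`: 33 nM

All three share a core, a four-membered ring with one nitrogen, and differ only in the groups attached to it. Compound 2 and compound 1 differ by hydrogen in place of vinyl on a saturated ring carbon. That change gave a 1.6-fold lower number from compound 2 to compound 1 (0.20 log units; within the scatter), so these two compounds cannot be told apart on this assay. Compound 2 and compound 3 differ by methoxy in place of ethylsulfanyl on an aromatic carbon, which gave a 9.7-fold lower number from compound 2 to compound 3 (0.99 log units; beyond the scatter), a clearer step.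

Compound 4, `COc1ccc(C2CC(=O)N2c2cc(OC)c(OC)c(OC)c2)cc1`, has not been measured. It differs from compound 3 by hydrogen in place of vinyl on a saturated ring carbon. Within the data shown here, this is the same kind of change as the one from compound 2 to compound 1, but the place is not identical: here it sits next to the ring atom that bears a 4-methoxyphenyl group, there next to the ring atom that bears a 4-(ethylsulfanyl)phenyl group.

The step from compound 3 to compound 4 is expected to be a 1.3-fold lower number from compound 3 to compound 4 (0.12 log units; within the scatter), a small one, because a 1.6-fold lower number from compound 2 to compound 1 (0.20 log units; within the scatter) stayed within the scatter. Compound 4 is therefore estimated at 25 nM, most likely between 10 nM and 60 nM.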

Compound 4, half-maximal inhibitory concentration: 76 nM
Beside the measured number, compound 4's estimate is 3.0-fold (0.48 log units) below it; measured number outside the range, above it.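

Hydrogen in place of vinyl on the saturated ring carbon gave a 2.3-fold higher number from compound 3 to compound 4 (0.36 log units; beyond the scatter) in this assay, a real loss of inhibition where the ethylsulfanyl pair showed no readable difference, so the size of this step depends on the core: the same change on two cores in this assay, a 1.6-fold lower number (0.20 log units; within the scatter) from compound 2 to compound 1 and a 2.3-fold higher number (0.36 log units; beyond the scatter) from compound 3 to compound 4, 3.6-fold (0.56 log units) apart, beyond the scatter of two such steps Methoxy in place of ethylsulfanyl gave a 2.7-fold lower number from compound 1 to compound 4 (0.43 log units; beyond the scatter), the same direction as on the vinyl-bearing core but a smaller step: the same change on two cores in this assay, a 9.7-fold lower number (0.99 log units; beyond the scatter) from compound 2 to compound 3 and a 2.7-fold lower number (0.43 log units; beyond the scatter) from compound 1 to compound 4, 3.6-fold (0.56 log units) apart, beyond the scatter of two such steps These four compounds therefore show that the methoxy compound is the stronger in both pairs but that neither step keeps its size from one core to the other, and they do not show why the two changes interact or whether this holds beyond these compounds.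

The compounds shown leave open whether an ethyl group on the saturated ring carbon would behave like vinyl. They also leave open whether an ethoxy group on the aromatic carbon would follow methoxy or ethylsulfanyl.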